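A Single Stereocentre Flipped in a Cytotoxic Natural Scaffold

A few compounds are considered here, and "the series" means these few. Any claim that something is new, unique, unknown or untested is made for them only; others in the source may bear on it.

Two measured compounds set the scene. In a functional assay on PC-12 cells (Rattus norvegicus) for cytotoxicity, read by MTT assay, with a stated time of 24 h (on this read-out higher numbers stand for weaker inhibition and lower numbers for stronger inhibition), compound 1 `CC(C)=C1CC[C@]2(C)CC[C@]3(O[C@H](C[C@@H]3C)C[C@]3(C)O[C@H]3C1=O)O2` gives 36400 nM, and compound 2 `CC(=O)O[C@]1(C)CCC(=C(C)C)C(=O)[C@@H]2O[C@@]2(C)C[C@H]2C[C@H](C)[C@@](O)(CC1)O2` gives 37100 nM; these two numbers sit within the scatter of repeated measurements, so neither can be ranked against the other. Compound 3 `CC(C)=C1CC[C@]2(C)CC[C@]3(O[C@H](C[C@H]3C)C[C@]3(C)O[C@H]3C1=O)O2` keeps every atom and bond of compound 1: the two compounds have the same atoms and bonds and differ only in configuration as drawn: 1 of 6 stereo elements differ; a stereocentre at a saturated ring carbon is drawn S in compound 1 and R in compound 3. For the measured compounds named here, no measured pair of this kind exists here to lean on, so in this assay the step is estimated as a 1.0-fold lower number from compound 1 to compound 3 (0.00 log units; within the scatter), essentially nothing beyond the scatter. Compound 3 is therefore expected to give about 36000 nM, between 15000 nM and 85000 nM.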

Compound 3, half-maximal inhibitory concentration: > 50000 nM
Compound 3: only a limit was reported; the forecaster's own chance of this, stated with the estimate: 10%; middle value at least 1.3-fold (0.14 log units) away from the limit.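

In this assay compound 3 gives > 50000 nM, which is a limit and not a number. Turning this one saturated ring carbon from S to R therefore gives an at least 1.3-fold higher number from compound 1 to compound 3 (0.13 log units; that floor lies within the scatter), the first reading of a change in configuration alone, though the true size of the step remains unknown. No atom or bond changes in this step, so only the drawn configuration separates the two compounds: the fact that compounds 1 and 3 differ only in the configuration as drawn

On these data alone, whether the real step goes beyond the scatter stays open. Also open, as far as these compounds go, is how an amine or a carboxylic acid on the shared core would read in this assay.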